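Methyl-to-methoxy swap on two nitro regioisomers: lipophilicity

The source may hold more compounds than are shown below. What is called first, only, known or untested is meant among the compounds shown, and "the series" means these compounds.

Measured in a physicochemical assay for lipophilicity; on this read-out higher numbers stand for higher lipophilicity and lower numbers for lower lipophilicity:
compound 1, `Cc1ccc(/C=C2\CCC/C(=C\c3cccc([N+](=O)[O-])c3)C2=O)cc1`, gives 5.35.
compound 2, `COc1ccc(/C=C2\CCC/C(=C\c3cccc([N+](=O)[O-])c3)C2=O)cc1`, gives 4.96.
compound 3, `Cc1ccc(/C=C2\CCC/C(=C\c3ccc([N+](=O)[O-])cc3)C2=O)cc1`, gives 5.38.

Compound 2 differs from compound 1 by methoxy in place of methyl on an aromatic carbon, and this change made a step of a number 0.39 log units lower from compound 1 to compound 2 (beyond the scatter). Compound 3 has the same atoms as compound 1 joined differently; the difference between the two cores is not broken down here. In this assay compound 3 and compound 1 lie within the scatter of each other, while compound 2 stands lower than both.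

Compound 4, `COc1ccc(/C=C2\CCC/C(=C\c3ccc([N+](=O)[O-])cc3)C2=O)cc1`, is not yet measured. It differs from compound 3 by methoxy in place of methyl on an aromatic carbon, the same change as between compound 1 and compound 2, at the same place. Since the same change gave a number 0.39 log units lower from compound 1 to compound 2 (beyond the scatter), the step from compound 3 to compound 4 in this assay is expected to be a number 0.39 log units lower from compound 3 to compound 4 (beyond the scatter). Compound 4 is therefore estimated at 4.99, most likely between 4.7 and 5.3.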

Compound 4, partition coefficient: 4.98
The estimate for compound 4 lay 0.01 log units above the measured number; measured number inside the range.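

In this assay, the swap of methyl for methoxy carried over from one core to the other: a number 0.40 log units lower from compound 3 to compound 4 (beyond the scatter) matches a number 0.39 log units lower from compound 1 to compound 2 (beyond the scatter) in direction and nearly in size. This is a single pair of cores that differ only in where the nitro group sits, so it supports transfer between these two cores and sets no rule for the wider series. Nothing available explains the step or why it repeats.

The compounds shown leave open whether an ethoxy or an amine at the same place would give a comparable step. As far as these compounds go, it is also open whether the step would hold on a core carrying a nitrile in place of the nitro group.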